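The source may report more compounds than this note shows. Statements on the series, on what has been measured and on what is new or still open speak of the compounds shown alone.

Of the compounds shown here, three built on one shared core have so far been tested in an ADME assay on CCRF-CEM cells (Homo sapiens) for antiproliferative activity, with a stated time of 48 h; on this read-out lower numbers stand for stronger inhibition and higher numbers for weaker inhibition. Compound 1 (`C=C(Br)C(=O)Nc1ccc(/C=C/C(=O)c2ccccc2)cc1`) gives 4000 nM, compound 2 (`C=C(Br)C(=O)Nc1ccc(/C=C/C(=O)c2ccc(Br)cc2)cc1`), which carries a bromo group, gives 990 nM, and compound 3 (`C=C(Br)C(=O)Nc1ccc(/C=C/C(=O)c2ccc(I)cc2)cc1`), which carries an iodo group on the same aromatic carbon, gives 4000 nM. Compound 3 therefore shares the highest number of the three with compound 1, and stands clearly above compound 2.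

The next compound is compound 4 (`C=C(Br)C(=O)Nc1ccc(/C=C/C(=O)c2ccc(OCC)cc2)cc1`), with ethoxy in place of iodo on an aromatic carbon. All three measured steps involve this same place. Bromo in place of hydrogen gives a 4.0-fold lower number from compound 1 to compound 2 (0.61 log units; beyond the scatter), iodo in place of hydrogen gives no change at the digits printed from compound 1 to compound 3 (within the scatter), and iodo in place of bromo gives a 4.0-fold higher number from compound 2 to compound 3 (0.61 log units; beyond the scatter). Changes here have therefore been modest at most, and they follow no steady direction. Among the measured compounds shown here, no tested compound carries ethoxy, so these steps suggest a likely size better than a direction. Compound 3 sits at the top of the measured numbers with 4000 nM, so a move toward lower numbers seems somewhat more likely than a move higher. The expected change is a 2.0-fold lower number from compound 3 to compound 4 (0.30 log units; within the scatter), no larger than the modest steps already seen. In this assay the estimate for compound 4 is 2000 nM, with an expected range from 700 nM to 5000 nM.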

Compound 4, half-maximal inhibitory concentration: 750 nM
Compound 4: the middle estimate sits 2.7-fold (0.43 log units) above what was measured, within the range that was stated.
By their numbers in this assay, from the lowest: compounds 4 and 2 (each within the scatter of the next); then compounds 1 and 3 (each within the scatter of the next).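

In this assay this place on the aromatic ring, para to a large group, now carries something other than a halogen, and ethoxy in place of iodo gives a 5.3-fold lower number from compound 3 to compound 4 (0.73 log units; beyond the scatter) and so lies beyond the scatter. Measured against the bare hydrogen, ethoxy gives a 5.3-fold lower number from compound 1 to compound 4 (0.73 log units; beyond the scatter) and is again beyond the scatter, whereas ethoxy in place of bromo gives a 1.3-fold lower number from compound 2 to compound 4 (0.12 log units; within the scatter) and stays within it. A halogen is therefore not needed for the number to fall at this place, and among the three groups shown here iodo is the one that leaves the number level with the hydrogen of compound 1.

The compounds shown leave open whether the oxygen or the carbons of ethoxy matter more, and whether a hydroxy group, a methoxy group, an amine or a longer chain such as butoxy would keep the number at this lower level. Nothing given here accounts for why bromo and ethoxy sit level while iodo does not.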